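Series notes: two measured compounds, one awaiting measurement

The source may report more compounds than this note shows. Statements on the series, on what has been measured and on what is new or still open speak of the compounds shown alone.

Measured in an assay (Rattus norvegicus) for inhibition of Fatty-acid amide hydrolase 1 (Homo sapiens); on this read-out higher numbers stand for weaker inhibition and lower numbers for stronger inhibition:
compound 1 `O=C(CCCCCCc1ccccc1)c1ncc(-c2ccc(C(=O)C(F)(F)F)cc2)o1` — 65 nM
compound 2 `Cc1cccnc1-c1cnc(C(=O)CCCCCCc2ccccc2)o1` — 15 nM

Compound 2 stands at the lowest of the two numbers; compound 1 sits higher, beyond the scatter. Compound 3 `O=C(CCCCCCc1ccccc1)c1ncc(Cl)o1` is not yet measured. It differs from compound 2 as follows: chloro in place of 3-methylpyridin-2-yl on an aromatic carbon. For the measured compounds named here, no measured pair tests this change, so no step is known for it. A move toward higher numbers beyond the scatter is expected in this assay, with a 10-fold higher number from compound 2 to compound 3 (1.00 log units; beyond the scatter). Compound 3 is estimated at 150 nM, ranging from 40 nM to 600 nM.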

Compound 3, inhibition constant: 5 nM
For compound 3 the middle estimate is 30-fold (1.48 log units) above the measured one, outside the stated range (below it).
By their numbers in this assay, from the lowest: compound 3; then compound 2; then compound 1.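

In this assay, the ring carbon next to the ring oxygen needs no aromatic ring for strong inhibition: chloro, a single heavy atom, replaces 3-methylpyridin-2-yl with a 3.0-fold lower number from compound 2 to compound 3 (0.48 log units; beyond the scatter). The larger group is therefore dispensable in this series at this position. Nothing available accounts for this step.

Open, from the compounds shown here alone, is whether the trend follows atom size: bromo, fluoro, methyl or plain hydrogen at this position would test that. Also open, going by these compounds, is how a carboxylic acid or an amine would fare there.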